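This account rests on a few compounds, and the source may have more. Where it says the series, first, only, none or still open, it means among the compounds named here.

Measured in a functional assay on PC-3 cells (Homo sapiens) for cytotoxicity, read by MTT assay, with a stated time of 48 h; a lower number here means a stronger inhibitor, a higher number a weaker inhibitor:
- compound 1 `Cc1ccc(C)c(/C=C/[C@](C)(O)CC[C@@H]2[C@@]3(C)CCCC(C)(C)[C@@H]3CC[C@@]2(C)O)c1`: 176 nM
- compound 2 `CC1(C)CCC[C@]2(C)[C@@H](CC[C@@](C)(O)/C=C/c3ccc(Br)cc3)[C@](C)(O)CC[C@@H]12`: 41300 nM

Of these two compounds, compound 2 has the higher number, 41300 nM, which makes it the weaker inhibitor of the pair. The gap is large: a 230-fold higher number from compound 1 to compound 2 (2.37 log units; beyond the scatter).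

The next compound, compound 3 `CC1(C)CCC[C@]2(C)[C@@H](CC[C@@](C)(O)/C=C/c3ccc(F)cc3)[C@](C)(O)CC[C@@H]12`, differs from compound 2 only in the group on the aromatic ring: fluoro in place of bromo on an aromatic carbon. This places fluoro in place of bromo on an aromatic carbon, para to a large group, turning 4-bromophenyl into 4-fluorophenyl.

For the measured compounds named here, only one measured step bears on this change, and only loosely. That step, a 230-fold higher number from compound 1 to compound 2 (2.37 log units; beyond the scatter), exchanged 2,5-dimethylphenyl for 4-bromophenyl. Going by the values given here, it shows that the aromatic group can matter greatly in this assay, but no measured compound carries fluoro, so its size cannot simply be carried over. A far smaller step is expected here, perhaps no larger than the scatter. The direction is tentatively downward, since compound 2 at 41300 nM sits at the high end of the numbers seen so far.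

The expected change is a 2.1-fold lower number from compound 2 to compound 3 (0.31 log units; beyond the scatter). For compound 3 the estimated value is 20000 nM, with an expected range from 2000 nM to 60000 nM.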

Compound 3, half-maximal inhibitory concentration: 82 nM
The estimate for compound 3 lay 240-fold (2.39 log units) above the measured number; measured number outside the range, below it.
By their numbers in this assay, from the lowest: compound 3; then compound 1; then compound 2.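

In this assay, the group on the aromatic carbon para to a large group turns out to weigh heavily: putting fluoro in place of bromo gives a 500-fold lower number from compound 2 to compound 3 (2.70 log units; beyond the scatter), even though each group is a single heavy atom with no ring, no hydrogen-bond donor or acceptor and no net charge. This changes how the earlier step reads, as the weak number of compound 2 cannot be pinned on losing the 2,5-dimethylphenyl group as such. With 4-fluorophenyl on the same chain, the step is only modest, a 2.1-fold lower number from compound 1 to compound 3 (0.33 log units; beyond the scatter), so a ring with one group para to the chain can nearly match or even pass the dimethyl ring, depending on which group it carries. Nothing at hand explains why bromo and fluoro lie so far apart.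

With only bromo and fluoro shown at this place, it remains open how chloro, a methoxy group or an amine would read there, and whether the numbers would form any trend or whether bromo stands alone. On these data alone, it also remains open whether fluoro would have as large an effect on a ring that keeps the two methyl groups of compound 1.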